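Chloro in Place of Methoxy on a Shared Core

The source may report more compounds than this note shows. Statements on the series, on what has been measured and on what is new or still open speak of the compounds shown alone.

Three compounds built on one shared core were tested in a functional assay on MCF7 cells (Homo sapiens) for antiproliferative activity, read by MTT assay, with a stated time of 48 h; a lower number here means a stronger inhibitor, a higher number a weaker inhibitor. Compound 1 `COc1ccc2nc(NC(c3cn(-c4ccccc4)nc3-c3ccc(Cl)cc3)c3c(O)ccc4ccccc34)sc2c1` gives 23700 nM, compound 2 `COc1ccc2nc(NC(c3cn(-c4ccccc4)nc3-c3ccc(F)cc3)c3c(O)ccc4ccccc34)sc2c1` gives 16900 nM, and compound 3 `COc1ccc(-c2nn(-c3ccccc3)cc2C(Nc2nc3ccc(OC)cc3s2)c2c(O)ccc3ccccc23)cc1` gives 41800 nM. Compound 2 and compound 3 differ by fluoro in place of methoxy on an aromatic carbon, and this gives a 2.5-fold higher number from compound 2 to compound 3 (0.39 log units; beyond the scatter). Compound 3 and compound 1 differ by chloro in place of methoxy on an aromatic carbon, giving a 1.8-fold lower number from compound 3 to compound 1 (0.25 log units; within the scatter).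

Compound 4 `Oc1ccc2ccccc2c1C(Nc1nc2ccc(Cl)cc2s1)c1cn(-c2ccccc2)nc1-c1ccc(F)cc1` has not yet been measured in this assay. It differs from compound 2 by chloro in place of methoxy on an aromatic carbon. Within the data shown here, this is the same kind of change as the one from compound 3 to compound 1, but not the same: there the place was para to a large group, whereas here it is part of a fused or bridged system of two rings, meta to a fused ring and para to a fused ring. The earlier swap gave a 1.8-fold lower number from compound 3 to compound 1 (0.25 log units; within the scatter). Resting on that single precedent, compound 4 is expected to show a 1.4-fold lower number from compound 2 to compound 4 (0.15 log units; within the scatter). Compound 4 is therefore estimated at 12000 nM, with a likely range from 5000 nM to 35000 nM.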

Compound 4, half-maximal inhibitory concentration: 21600 nM
For compound 4 the middle estimate is 1.8-fold (0.26 log units) below the measured one; the range from low to high includes it.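

In this assay, chloro in place of methoxy, here turning a 6-methoxy-1,3-benzothiazol-2-yl group into a 6-chloro-1,3-benzothiazol-2-yl group, gives a 1.3-fold higher number from compound 2 to compound 4 (0.11 log units; within the scatter). Set beside the same swap at the other place, the two results cannot be told apart: the same change on two cores in this assay, a 1.8-fold lower number (0.25 log units; within the scatter) from compound 3 to compound 1 and a 1.3-fold higher number (0.11 log units; within the scatter) from compound 2 to compound 4, 2.3-fold (0.35 log units) apart, within the scatter of two such steps. Among these compounds, this shows that the swap left no readable mark on either core, but with only two pairs, it does not show that the change has the same true effect on both or that this would hold on other cores.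

On these data alone, whether an amine or a carboxylic acid at this place would give a step beyond the scatter remains open. The same question stands for a longer chain there.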